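This account rests on a few compounds, and the source may have more. Where it says the series, first, only, none or still open, it means among the compounds named here.

Measured so far:
compound 1 `C=CCc1cc(OC)c(OC(C)C(OC2CCCCC2)c2ccc(O)c(OC)c2)c(OC)c1`: 54 nM
compound 2 `C=CCc1cc(OC)c(OC(C)C(OCCOCCCC)c2ccc(O)c(OC)c2)c(OC)c1`: 153 nM
compound 3 `C=CCc1cc(OC)c(OC(C)C(OCCCCCCCCCC)c2ccc(O)c(OC)c2)c(OC)c1`: 66 nM

In an assay on HEK293 cells for agonist activity at transient receptor potential cation channel subfamily M member 8 (Homo sapiens), read by fluorescence and calcium flux, with a stated time of 5 min (on this read-out lower numbers stand for an effect already at smaller amounts and higher numbers for an effect only at larger amounts of compound), compound 3 gives 66 nM and stands second highest of the three numbers. Its nearest neighbour is compound 1, since a 1.2-fold higher number from compound 1 to compound 3 (0.09 log units; within the scatter); its furthest is compound 2, since a 2.3-fold lower number from compound 2 to compound 3 (0.37 log units; beyond the scatter).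

The next compound is compound 4 `C=CCc1cc(OC)c(OC(C)C(OCC(C)C)c2ccc(O)c(OC)c2)c(OC)c1`. Relative to compound 3 the difference is isopropyl in place of nonyl on a saturated chain carbon bound to an oxygen on a saturated carbon.

Within the data shown here, three measured steps bear on the group carried by the oxygen on the saturated carbon. Cyclohexyl and decyl are interchangeable within the scatter, as a 1.2-fold higher number from compound 1 to compound 3 (0.09 log units; within the scatter) shows. Putting 2-butoxyethyl in that place gave a 2.8-fold higher number from compound 1 to compound 2 (0.45 log units; beyond the scatter), and the octyl-for-butoxy exchange gave a 2.3-fold lower number from compound 2 to compound 3 (0.37 log units; beyond the scatter), both modest. Among the measured compounds shown here, none of the measured compounds carries a group as short as isobutyl, so the direction of the step is not fixed by the data; the tolerance between cyclohexyl and decyl argues for a small change at most, while the weaker number of compound 2 leaves room for a modest loss.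

Compound 4 is therefore expected to come in near 110 nM in this assay, with a range of 45 nM to 270 nM. This estimate means a step of a 1.7-fold higher number from compound 3 to compound 4 (0.22 log units; within the scatter), expected to be modest and possibly within the scatter.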

Compound 4, half-maximal effective concentration: 138 nM
The estimate for compound 4 lay 1.3-fold (0.10 log units) below the measured number; low and high end bracket the measured number.
By their numbers in this assay, from the lowest: compounds 1 and 3 (each within the scatter of the next); then compounds 4 and 2 (each within the scatter of the next).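

In this assay, among these compounds, isobutyl in place of decyl on the oxygen gives a 2.1-fold higher number from compound 3 to compound 4 (0.32 log units; beyond the scatter) and is the first measured step to show that chain length at this position can matter, since cyclohexyl and decyl had matched each other. The comparison with cyclohexyl reads the same way (a 2.6-fold higher number from compound 1 to compound 4 (0.41 log units; beyond the scatter)), whereas isobutyl and 2-butoxyethyl stay together (a 1.1-fold lower number from compound 2 to compound 4 (0.04 log units; within the scatter)), so the four compounds fall into two groups at this position: compounds 1 and 3 with cyclohexyl and decyl, and compounds 2 and 4 with 2-butoxyethyl and isobutyl. No supporting measurement is available to explain this grouping, which stands only as a description of these four compounds.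

As far as these compounds go, whether a chain of intermediate length such as hexyl already matches decyl, and whether a shorter group such as ethyl or methyl continues the step seen with isobutyl, remains open. Also open, from the compounds shown here alone, is how this position responds to an amine or a carboxylic acid at the end of the chain.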